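This account rests on a few compounds, and the source may have more. Where it says the series, first, only, none or still open, it means among the compounds named here.

Measured so far:
- compound 2 `O=C(Nc1noc2cnccc12)N1CCN(Cc2cccc(Oc3ccc(Cl)cc3)c2)CC1`, which in an assay on isolated protein for inhibition of Fatty-acid amide hydrolase 1 (Homo sapiens), with a stated time of 60 min (a higher number here means a weaker inhibitor, a lower number a stronger inhibitor), gives 0.5 nM
- compound 1 `O=C(Nc1cncc2ccccc12)N1CCN(Cc2cccc(Oc3ccc(Cl)cc3)c2)CC1`, which in this assay gives 6.7 nM

For the measured compounds named here, of the two numbers in hand, compound 2 has the lower one; the only other compound, compound 1, sits a clear way above it, as the step of a 13-fold lower number from compound 1 to compound 2 (1.13 log units; beyond the scatter) shows. Compound 3 `O=C(Nc1noc2ccncc12)N1CCN(Cc2cccc(Oc3ccc(Cl)cc3)c2)CC1` is built from compound 2 by rearranging the bicyclic group on the urea nitrogen: a group of 9 heavy atoms (6 carbon, 2 nitrogen, 1 oxygen; one five-membered aromatic ring with 2 hetero atoms, one six-membered aromatic ring with 1 hetero atom) in place of a group of 9 heavy atoms (6 carbon, 2 nitrogen, 1 oxygen; one five-membered aromatic ring with 2 hetero atoms, one six-membered aromatic ring with 1 hetero atom), on an amide-type nitrogen. Going by the values given here, the one measured step swapped a wholly different group onto that same nitrogen, so it does not speak to a rearrangement of the same atoms, and there is no measured pair to lean on. Moving a ring nitrogen within an otherwise identical group often changes little, but sometimes changes much. A modest rise is therefore expected for compound 3, a 2.4-fold higher number from compound 2 to compound 3 (0.38 log units; beyond the scatter), with wide uncertainty. Compound 3 is estimated at 1.2 nM in this assay, most likely between 0.25 nM and 6 nM.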

Compound 3, half-maximal inhibitory concentration: 180 nM
Estimate against measurement, compound 3: 150-fold (2.18 log units) below, and the stated range ends below it.
By their numbers in this assay, from the lowest: compound 2; then compound 1; then compound 3.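

Compound 2 and compound 3 have the same atoms and the same counts of hydrogen-bond donors and acceptors, yet in this assay there is a 360-fold higher number from compound 2 to compound 3 (2.56 log units; beyond the scatter). At this position on the amide-type nitrogen, then, how the atoms of the group are joined matters greatly, not only which atoms are present. The step of a 27-fold higher number from compound 1 to compound 3 (1.43 log units; beyond the scatter) also shows that swapping in a group with a five-membered aromatic ring does not by itself give a lower number, since compound 2 and compound 3 fall on opposite sides of compound 1, and nothing available explains this large gap.

Still open, as far as these compounds go, is how a further arrangement of the same atoms would behave. From the compounds shown here alone, it is also open whether sulfur in place of the ring oxygen, or a methyl group on the six-membered ring, would keep the low number of compound 2.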